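The compounds below may be only part of what the source reports. "The series", "measured", "known", "first", "only" and "open" are said of these compounds alone.

Compound 2 `CCOC(=O)C1=Cc2ccccc2OC1(OCc1cc(-c2ccc(OC)cc2)no1)C(F)(F)F` is the ethyl ester carrying a 4-methoxyphenyl group. In a functional assay on MCF7 cells (Homo sapiens) for inhibition, read by MTT assay, with a stated time of 24 h (on this read-out lower numbers stand for stronger inhibition and higher numbers for weaker inhibition), compound 2 reaches only the limit of the assay, > 150000 nM. For the measured compounds named here, compound 2 is the single value among the three measured that sits at the limit of > 150000 nM in this assay, at which 1 of the 3 values shown sits. Its acid counterpart compound 3 `COc1ccc(-c2cc(COC3(C(F)(F)F)Oc4ccccc4C=C3C(=O)O)on2)cc1` gives 35200 nM in this assay, the step being an at least 4.2-fold lower number from compound 2 to compound 3 (0.62 log units; beyond the scatter). Compound 1 `O=C(O)C1=Cc2ccccc2OC1(OCc1cc(-c2ccc(F)cc2)no1)C(F)(F)F`, the acid with fluoro in place of methoxy, gives 64200 nM in this assay. Compound 4 `CCOC(=O)C1=Cc2ccccc2OC1(OCc1cc(-c2ccc(Cl)cc2)no1)C(F)(F)F` differs from compound 2 by chloro in place of methoxy on an aromatic carbon. Going by the values given here, the only measured step that bears on this change of the aromatic substituent, a 1.8-fold lower number from compound 1 to compound 3 (0.26 log units; within the scatter), was within the scatter, so no step beyond the scatter is expected here. Compound 4 is therefore estimated near the limit, with a number no higher from compound 2 to compound 4 (the limit leaves the size open) and an expected value of 150000 nM, ranging from 60000 nM to 300000 nM.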

Compound 4, half-maximal inhibitory concentration: 18200 nM
The estimate for compound 4 lay 8.2-fold (0.92 log units) above the measured number; measured number below the stated range.
By their numbers in this assay, from the lowest: compounds 4, 3 and 1 (each within the scatter of the next, the first and the last beyond it). At a limit, above all of these: compound 2.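

The change from 4-methoxyphenyl to 4-chlorophenyl on the ethyl ester gives an at least 8.2-fold lower number from compound 2 to compound 4 (0.91 log units; beyond the scatter) and so shows that the group at this place can move the number beyond the scatter. The earlier step here, between the two acids, was a 1.8-fold lower number from compound 1 to compound 3 (0.26 log units; within the scatter) and showed no such move, while compound 4 shows that an ethyl ester need not sit at the limit. Compound 2 itself gives a limit and not a number: the limit of > 150000 nM in this assay, at which 1 of the 4 values shown sits.

As far as these compounds go, whether chloro acts alike on the carboxylic acid stays open. So does what an amine or a longer chain would give at this place.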